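A few compounds are considered here, and "the series" means these few. Any claim that something is new, unique, unknown or untested is made for them only; others in the source may bear on it.

Compound 1 `COc1cccc(-c2cnc(NC(=O)c3ccc(F)cc3)n2C)c1`: in a toxicity assay on THP-1 cells (Homo sapiens) for inhibition (a higher number here means that more compound is tolerated, a lower number that less compound is tolerated), compound 1 reaches only the assay limit, > 100000 nM. Compound 2 `Cn1c(-c2ccc(Cl)cc2)cnc1NC(=O)c1ccc(F)cc1`: in this assay compound 2 gives 37000 nM.

Compound 2 thus holds the only true number shown, the other value being a limit. Compound 3 `COc1ccc(-c2cnc(NC(=O)c3ccc(F)cc3)n2C)cc1` differs from compound 2 by methoxy in place of chloro on an aromatic carbon. Within the data shown here, the single measured step bearing on this is an at least 2.7-fold lower number from compound 1 to compound 2 (0.43 log units; beyond the scatter), where the methoxy-bearing compound sat at the limit (the limit of > 100000 nM in this assay, at which 1 of the 2 values shown sits). Bringing a methoxy group back in compound 3 is therefore expected to move the number upward, a 2.2-fold higher number from compound 2 to compound 3 (0.33 log units; beyond the scatter). Compound 3 is estimated at 80000 nM, within 30000 nM to 150000 nM, with a real chance of reaching the limit again.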

Compound 3, half-maximal cytotoxic concentration: >= 50000 nM
Compound 3 gave a limit, no number; the forecaster's own chance of this, stated with the estimate: 40%; the middle value does not contradict the limit.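

Methoxy in place of chloro, on an aromatic carbon para to a large group, gives an at least 1.3-fold higher number from compound 2 to compound 3 (0.13 log units; that floor lies within the scatter), so a real rise at this position is possible but not established. The result for compound 3 in this assay is a limit, not a number: the limit of >= 50000 nM in this assay, at which 1 of the 3 values shown sits.

The step between compound 1 and compound 3 cannot be read, so the move from 3-methoxyphenyl to 4-methoxyphenyl has no readable size. From the compounds shown here alone, what remains open is where the true value of compound 3 lies, and how an amine or a carboxylic acid on this same aromatic carbon would read.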